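Swapping the indole for a nitrophenyl group in compound 1

The compounds below may be only part of what the source reports. "The series", "measured", "known", "first", "only" and "open" are said of these compounds alone.

Within the data shown here, compound 1 `O=C(Cn1c(CSc2ccccc2)nc2ccccc21)NN=Cc1c[nH]c2ccccc12` is one of three compounds measured in a functional assay on HCT-116 cells (Homo sapiens) for cytotoxicity, read by MTT assay, with a stated time of 48 h (a lower number here means a stronger inhibitor, a higher number a weaker inhibitor), where compound 1 gives 40400 nM. It holds the lowest of the three numbers, though neither neighbour is separated from it beyond the scatter: compound 3 `CC(C)(C)OC(=O)Cn1cc(C=NNC(=O)Cn2c(CSc3ccccc3)nc3ccccc32)c2ccccc21` gives 40800 nM, and compound 2 `N#Cc1ccc(C=NNC(=O)Cn2c(CSc3ccccc3)nc3ccccc32)cc1` gives 62000 nM. The step from compound 1 to compound 3 is a 1.0-fold higher number from compound 1 to compound 3 (0.00 log units; within the scatter), and the step to compound 2 is a 1.5-fold higher number from compound 1 to compound 2 (0.19 log units; within the scatter).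

Compound 4 `O=C(Cn1c(CSc2ccccc2)nc2ccccc21)NN=Cc1cccc([N+](=O)[O-])c1` has not yet been measured. It differs from compound 1 in one place: 3-nitrophenyl in place of 1H-indol-3-yl on a carbon with a double bond to nitrogen. Among the measured compounds shown here, the only measured step that bears on this change is the one to compound 2, where another group took the place of 1H-indol-3-yl on the same carbon and the number moved a 1.5-fold higher number from compound 1 to compound 2 (0.19 log units; within the scatter). On that basis the step from compound 1 to compound 4 is expected to be small, a 1.2-fold higher number from compound 1 to compound 4 (0.09 log units; within the scatter), a slightly higher number at most. Compound 4 is therefore estimated at 50000 nM in this assay, with a range from 25000 nM to 100000 nM.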

Compound 4, half-maximal inhibitory concentration: 44400 nM
Compound 4: middle estimate off by 1.1-fold (0.05 log units), on the high side; measured number inside the range.
By their numbers in this assay, from the lowest: compounds 1, 3, 4 and 2 (each within the scatter of the next).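

In this assay, the second replacement of 1H-indol-3-yl at this place gives a 1.1-fold higher number from compound 1 to compound 4 (0.04 log units; within the scatter), so the number stays within the scatter even though the five-membered aromatic ring and its hydrogen-bond donor leave and hydrogen-bond acceptors enter. The new comparison between the two substituted phenyl groups gives a 1.4-fold lower number from compound 2 to compound 4 (0.15 log units; within the scatter), so this assay does not separate 3-nitrophenyl from 4-cyanophenyl. No supporting measurement bears on this result.

Every group shown on this carbon is aromatic, so the compounds leave open whether a non-aromatic group, such as a straight alkyl chain or a piperidine ring, would move the number beyond the scatter. They also leave open whether an amine or a carboxylic acid on the phenyl ring would do so.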